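A few compounds are considered here, and "the series" means these few. Any claim that something is new, unique, unknown or untested is made for them only; others in the source may bear on it.

Measured so far in a functional assay on KG-1 cells (Homo sapiens) for cytotoxicity, read by luminescence and CellTiter-Glo, with a stated time of 3 days; on this read-out lower numbers stand for stronger inhibition and higher numbers for weaker inhibition:
compound 1 `N#Cc1ccc(NC(=O)c2ccc(F)cc2O)cc1`, 3150 nM
compound 2 `O=C(Nc1ccc(OC(F)(F)F)cc1)c1cc(F)ccc1O`, 780 nM
compound 3 `O=C(Nc1ccc(C(F)(F)F)cc1)c1ccc(F)cc1O`, 740 nM

Compound 1 gives the highest of the three numbers; compound 2 lies nearer to it and compound 3 furthest, both gaps beyond the scatter. For the measured compounds named here, the only step recorded is a 4.3-fold lower number from compound 1 to compound 3 (0.63 log units; beyond the scatter), a change at the cyano end of the shared core. Compound 4 `N#Cc1ccc(NC(=O)c2ccc(-c3ccccc3)cc2O)cc1` differs from compound 1 on the other ring: phenyl in place of fluoro on an aromatic carbon. Going by the values given here, no measured step touches this part of the core, and a phenyl group is new to the series, so the recorded step gives no direct guidance. With nothing to rest on, no direction beyond the scatter is assumed, and the range is kept wide. Compound 4 is expected in this assay to give about 2000 nM, between 500 nM and 8000 nM. The expected step is a 1.6-fold lower number from compound 1 to compound 4 (0.20 log units; within the scatter).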

Compound 4, half-maximal inhibitory concentration: 410 nM
Compound 4: middle estimate off by 4.9-fold (0.69 log units), on the high side; the whole stated range lies above it.
By their numbers in this assay, from the lowest: compounds 4, 3 and 2 (each within the scatter of the next); then compound 1.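

In this assay, the position para to a large group and meta to a hydroxy group accepts phenyl in place of fluoro, giving a 7.7-fold lower number from compound 1 to compound 4 (0.89 log units; beyond the scatter) without any change at the cyano end. The number therefore responds to this ring of the shared core as well, and a group of six heavy atoms is accepted here. No measurement on hand accounts for the step.

An amine or a methoxy group at this position remains untested in the compounds shown. Also open, on these data alone, is whether phenyl here combines with trifluoromethyl in place of cyano.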